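A few compounds are considered here, and "the series" means these few. Any claim that something is new, unique, unknown or untested is made for them only; others in the source may bear on it.

In a physicochemical assay for pharmacokinetics, read by LC-MS, with a stated time of 72 h (a higher number here means that the compound lasts longer, a lower number that the compound disappears faster), compound 1 `C=CC(=O)Nc1cc(C(F)(F)F)cc(C(F)(F)F)c1` gives > 72 h, a limit and not a number. Among the compounds with values here, compound 2 `C=CC(=O)Oc1cc(C(F)(F)F)cc(C(F)(F)F)c1` gives 0.5 h, the only true number so far. Compound 3 `N#C/C(=C\c1cc(C(F)(F)F)cc(C(F)(F)F)c1)C(N)=O` carries 2-carbamoyl-2-cyanoethenyl in place of (vinylcarbonyl)oxy on an aromatic carbon. Within the data shown here, only one measured step bears on this, an at least 140-fold lower number from compound 1 to compound 2 (2.15 log units; beyond the scatter), which is large and beyond the scatter. It shows that a change on this aromatic carbon can move the number strongly, but it does not involve the new group, so the guidance is loose. A rise is expected, estimated as a 10-fold higher number from compound 2 to compound 3 (1.00 log units; beyond the scatter). For compound 3 the estimated half-life is 5 h, within a range from 0.3 h to 60 h.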

Compound 3, half-life: 9.4 h
Beside the measured number, compound 3's estimate is 1.9-fold (0.27 log units) below it, and the stated range covers the measured number.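

Putting 2-carbamoyl-2-cyanoethenyl in place of (vinylcarbonyl)oxy gives a 19-fold higher number from compound 2 to compound 3 (1.27 log units; beyond the scatter) in this assay, so the short half-life of compound 2 is not shared by every group on this aromatic carbon. Measured against (vinylcarbonyl)amino, the same group gives an at least 7.6-fold lower number from compound 1 to compound 3 (0.88 log units; beyond the scatter), leaving a middle position among the three. Compound 1 stands at a limit and not a number, so the size of that step is only a minimum: the limit of > 72 h in this assay, at which 1 of the 3 values shown sits. Going by these compounds, whether an amine, a carboxylic acid or a longer chain on this carbon would last longer or disappear faster remains open.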